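A few compounds are considered here, and "the series" means these few. Any claim that something is new, unique, unknown or untested is made for them only; others in the source may bear on it.

Measured in a functional assay on UACC-62 cells (Homo sapiens) for inhibition, read by sulforhodamine B assay, with a stated time of 48 h; on this read-out lower numbers stand for stronger inhibition of growth and higher numbers for weaker inhibition of growth:
compound 1 `CC1=CC[C@H](C(C)(C)N=C=S)CC1`: "not determined" (no result reported).
compound 2 `COc1ccc(/C=N/NC(=S)NC(C)(C)[C@H]2CC=C(C)CC2)cc1`: 70400 nM.
compound 3 `CC1=CC[C@H](C(C)(C)NC(=S)N/N=C/c2ccc(Cl)cc2)CC1`: > 100000 nM, which is a limit of the assay and not a number.

For the measured compounds named here, compound 2 therefore holds the only plain number in this assay; one further value is a limit and one entry has no result. Compound 4 `CC1=CC[C@H](C(C)(C)NC(=S)N/N=C/c2ccco2)CC1` differs from compound 2 by furan-2-yl in place of 4-methoxyphenyl on a carbon with a double bond to nitrogen. Going by the values given here, the one measured step, an at least 1.4-fold higher number from compound 2 to compound 3 (0.15 log units; that floor lies within the scatter), concerns a different exchange on the same aryl ring and has a floor that lies within the scatter, so it gives little guidance for swapping the whole ring. A small shift toward weaker inhibition is expected in this assay, a 1.3-fold higher number from compound 2 to compound 4 (0.11 log units; within the scatter), not clearly beyond the scatter. Compound 4 is estimated at 90000 nM, within 35000 nM to 230000 nM.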

Compound 4, concentration for total growth inhibition: 14100 nM
Estimate against measurement, compound 4: 6.4-fold (0.81 log units) above; the whole stated range lies above it.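

In this assay, for the compounds shown here, the ring on the carbon with a double bond to nitrogen proves to matter: furan-2-yl in place of 4-methoxyphenyl gives a 5.0-fold lower number from compound 2 to compound 4 (0.70 log units; beyond the scatter) and so stronger inhibition of growth, the first step here beyond the scatter. Against 4-chlorophenyl the same exchange gives an at least 7.0-fold lower number from compound 3 to compound 4 (0.85 log units; beyond the scatter) as a floor only. (The value of compound 3 is a limit and not a number: the limit of > 100000 nM in this assay, at which 1 of the 4 values shown sits)

On these data alone, whether a thiophene ring, a pyridine ring or a plain phenyl ring would behave like furan-2-yl stays open. So does whether an amine on the furan ring would shift the number further.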